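The source may hold more compounds than are shown below. What is called first, only, known or untested is meant among the compounds shown, and "the series" means these compounds.

Compound 3 `CCOC(=O)c1cnc(N2CCN(Cc3ccc(C(=O)OC)cc3)CC2)nc1Oc1c(C)cc(-c2ccc(C#N)cc2)cc1C` is one of three close analogues that differ only in the group carried on a saturated chain carbon bound to an amine nitrogen in a ring. In an ADME assay on MT4 cells (Homo sapiens) for cytotoxicity, read by MTT assay, with a stated time of 4 days (on this read-out higher numbers stand for lower toxicity in this test and lower numbers for higher toxicity in this test), compound 3 gives > 125000 nM, which is a limit of the assay rather than a number. Compound 1 `CCOC(=O)c1cnc(N2CCN(Cc3ccc(C#N)cc3)CC2)nc1Oc1c(C)cc(-c2ccc(C#N)cc2)cc1C` gives > 125000 nM in this assay, again a limit. Compound 2 `CCOC(=O)c1cnc(N2CCN(Cc3cccc(C#N)c3)CC2)nc1Oc1c(C)cc(-c2ccc(C#N)cc2)cc1C` gives > 125000 nM in this assay, also a limit. The steps between them, a step that the two limits leave unreadable from compound 1 to compound 2, a step that the two limits leave unreadable from compound 1 to compound 3 and a step that the two limits leave unreadable from compound 2 to compound 3, are for that reason not readable in size, and what the three values share is the limit of > 125000 nM in this assay, at which 3 of the 3 values shown sit. Compound 4 `CCOC(=O)c1cnc(N2CCN(Cc3ccccc3[N+](=O)[O-])CC2)nc1Oc1c(C)cc(-c2ccc(C#N)cc2)cc1C` is the next member; its difference from compound 3 is 2-nitrophenyl in place of 4-(methoxycarbonyl)phenyl on a saturated chain carbon bound to an amine nitrogen in a ring. Within the data shown here, none of the measured steps can be read as a change beyond the scatter, and each of them, like the change to compound 4, concerns only the group on that saturated chain carbon. Compound 4 is accordingly expected to sit at the same limit in this assay, with a step of a number no higher from compound 3 to compound 4 (the limit leaves the size open) of no real size. The estimate for compound 4 in this assay is 125000 nM, with a range from 60000 nM to 250000 nM, and the reported figure is expected most likely to be a limit once more.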

Compound 4, half-maximal cytotoxic concentration: >= 78700 nM
Compound 4: a limit, no number; the forecaster's own chance of this, stated with the estimate: 80%; the middle value does not contradict the limit.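

In this assay compound 4 gives >= 78700 nM, which is a limit and not a number. Among these compounds, with compound 1, compound 2 and compound 3 also at limits, no step from any of them to compound 4 can be read in size. The compounds shown leave open whether the group on that saturated chain carbon changes the read-out in this assay at all.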